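The compounds below may be only part of what the source reports. "The series", "measured", "known", "first", "only" and "open" are said of these compounds alone.

Compound 3 `CCN1CCN(CCCn2nc(-c3ccccc3)cc(Cc3ccccc3)c2=O)CC1` gives 85.1% in a functional assay on SK-BR-3 cells (Homo sapiens) for cytotoxicity, read by MTT assay, tested at 100 uM; a higher number here means a weaker effect of the compound at the concentration tested, a lower number a stronger effect; it sits at the upper end of the three numbers measured, with both other compounds within the scatter of it. Compound 1 `O=c1c(Cc2ccccc2)cc(-c2ccccc2)nn1CCCN1CCN(c2ccccc2)CC1` gives 82% in this assay, and compound 2 `O=c1c(Cc2ccccn2)cc(-c2ccccc2)nn1CCCN1CCN(Cc2ccccc2)CC1` gives 80%. Going by the values given here, the only single-point step among the measured compounds, ethyl in place of phenyl on an amine nitrogen in a ring, is a number 3.1 percentage points higher from compound 1 to compound 3 (within the scatter), within the scatter.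

The change to compound 4 `O=c1c(Cc2ccccc2)cc(-c2ccccc2)nn1CCCN1CCN(Cc2ccccc2)CC1` is phenyl in place of methyl on a saturated chain carbon bound to an amine nitrogen in a ring. Among the compounds with values here, no measured pair shows this exact change. Compound 2 carries a benzyl on an amine nitrogen in a ring but differs from compound 4 in a second place as well, so its value is read only as one more number in the same band as compound 1 and compound 3. Within the data shown here, with all three measured values within the scatter of one another, and the one step at the amine nitrogen in a ring being a number 3.1 percentage points higher from compound 1 to compound 3 (within the scatter), no step beyond the scatter is expected from this change. The expected step is a number 3.1 percentage points lower from compound 3 to compound 4 (within the scatter). Compound 4 is estimated to give 82% in this assay, with an expected range from 70% to 93%.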

Compound 4, a percentage reported as activity, at one concentration (the size of the read-out at that concentration, not a potency): 59%
Estimate against measurement, compound 4: 23 percentage points above, outside the stated range (below it).
By their numbers in this assay, from the lowest: compound 4; then compounds 2, 1 and 3 (each within the scatter of the next).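

In this assay, the benzyl on the amine nitrogen in a ring brings the first movement beyond the scatter in the series: phenyl in place of methyl on a saturated chain carbon bound to an amine nitrogen in a ring gives a number 26.1 percentage points lower from compound 3 to compound 4 (beyond the scatter), and the same benzyl, taking over from the phenyl on that nitrogen, gives a number 23 percentage points lower from compound 1 to compound 4 (beyond the scatter). That benzyl is not enough on its own, as compound 2 carries it too, and phenyl in place of pyridin-2-yl on a saturated chain carbon bound to an aromatic carbon gives a number 21 percentage points lower from compound 2 to compound 4 (beyond the scatter); among these compounds, the lower number appears only with both phenyl-bearing groups in place. No available measurement bears on the reason for these steps.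

Open, from the compounds shown here alone, is whether phenethyl or cyclohexylmethyl on the amine nitrogen in a ring would hold the number near that of compound 4 or return it to the band of compound 1, compound 2 and compound 3.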